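A few compounds are considered here, and "the series" means these few. Any claim that something is new, unique, unknown or untested is made for them only; others in the source may bear on it.

Measured compounds:
compound 1 `COc1ccc(Nc2cc(C(C)C)oc(=O)c2)cc1` — in a functional assay on KBVIN cells (Homo sapiens) for cytotoxicity, read by MTT assay, with a stated time of 72 h (a higher number here means that more compound is needed for the effect, a lower number that less compound is needed), compound 1 gives > 30 uM
compound 2 `COc1ccccc1Nc1cc(-c2ccccc2)oc(=O)c1` — in this assay compound 2 gives 0.49 uM
compound 3 `O=c1cc(NC2CCCCC2)cc(/C=C/c2ccccc2)o1` — in this assay compound 3 gives 1.24 uM

Among the compounds with values here, compound 1 stands apart from the other two: its value in this assay is not a number but a limit of the assay, and it is the one compound that sits there (the limit of > 30 uM in this assay, at which 1 of the 3 values shown sits). Compound 2 and compound 3, which carry a phenyl and a styryl group on the shared core in place of the isopropyl of compound 1, are both measured as numbers in this assay, compound 2 at 0.49 uM and compound 3 at 1.24 uM.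

The unmeasured compound 4 `CCCCCc1cc(Nc2ccc(OC)cc2)cc(=O)o1` keeps the methoxyphenylamino side of compound 1 and alters the group on the core: pentyl in place of isopropyl on an aromatic carbon. Within the data shown here, no measured pair in this set differs in just that way, so the size of the step in this assay cannot be read from a comparison; the account can only say that compound 1 gives a limit and that compound 2 and compound 3 give numbers with other groups in that place. A modest move toward a measurable number is expected, with wide uncertainty, and a limit remains a real possibility.

The estimate for compound 4 is 20 uM, with a range of 5 uM to 60 uM. The step from compound 1 to compound 4 that this estimate means is expected to be an at least 1.5-fold lower number from compound 1 to compound 4 (0.17 log units; that floor lies within the scatter).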

Compound 4, concentration for half-maximal effect: 4.84 uM
Beside the measured number, compound 4's estimate is 4.1-fold (0.62 log units) above it; measured number below the stated range.
By their numbers in this assay, from the lowest: compound 2; then compound 3; then compound 4. At a limit, above all of these: compound 1.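

In this assay, the exchange of isopropyl for pentyl on the aromatic carbon next to the ring oxygen gives an at least 6.1-fold lower number from compound 1 to compound 4 (0.79 log units; beyond the scatter), and it does so with the methoxyphenylamino side held fixed. Within the data shown here, this is the first comparison that isolates this position: compound 2 and compound 3 also gave numbers, but they differ from compound 1 in more than one place, so they could not show that a change here alone is enough to move the series from a limit to a measured number. The printed step is only a floor, not a measured gap, and compound 1 remains the one compound at a limit: the limit of > 30 uM in this assay, at which 1 of the 4 values shown sits.

On these data alone, whether the number keeps falling with a longer chain such as heptyl, or how a branched chain of the same size as pentyl or a terminal amine on the chain would read, stays open. Among these compounds, compound 2 and compound 3 also differ from compound 4 in more than one place, so no step between them and compound 4 can be read, and a single change cannot be traced through these compounds.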